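The compounds below may be only part of what the source reports. "The series", "measured", "known", "first", "only" and "open" are said of these compounds alone.

Compound 1, `CCCCCOC(=O)N1CCN(C(=O)[C@H](CCC(=O)O)NC(=O)c2cc(N3CCC(C(=O)NCC)CC3)nc(-c3ccccc3)n2)CC1`, was tested in an ADME assay on microsomes from liver (Homo sapiens) for metabolic stability; on this read-out lower numbers stand for a less stable compound and higher numbers for a more stable compound. In this assay compound 1 gives > 80%, which is a limit of the assay and not a number. Two close relatives were measured as well. Compound 2, `CCCCCOC(=O)N1CCN(C(=O)[C@H](CCC(=O)O)NC(=O)c2nc(-c3ccccc3)cc(N3CCC(CN)CC3)n2)CC1`, gives > 80% in this assay, again a limit. Compound 3, `CCCCCOC(=O)N1CCN(C(=O)[C@H](CCC(=O)O)NC(=O)c2nc(-c3ccccc3)cc(N3CCC(COC)CC3)n2)CC1`, gives > 80% in this assay, also a limit. Within the data shown here, the one step between measured compounds, a step that the two limits leave unreadable from compound 2 to compound 3, cannot be read because of the limit of > 80% in this assay, at which 3 of the 3 values shown sit. Compound 1 therefore stands at the same limit as the two other values shown, and no order among the three can be drawn from them.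

Compound 4, `CCCCCOC(=O)N1CCN(C(=O)[C@H](CCC(=O)O)NC(=O)c2cc(N3CCC(CNC)CC3)nc(-c3ccccc3)n2)CC1`, differs from compound 1 in one place: (methylamino)methyl in place of ethylcarbamoyl on a saturated ring carbon. Among the measured compounds shown here, no measured step covers this exchange, and the single measured step is itself unreadable. With every value sitting at the limit, the expectation for compound 4 in this assay can rest only on that: compound 4 is expected to stay at the limit as well, so that a step that the limit leaves unreadable from compound 1 to compound 4 is expected to be small. Compound 4 is therefore estimated at 85%, within a range from 68% to 97%.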

Compound 4, percent of the compound remaining: > 80%
Compound 4: a limit, no number; the forecaster's own chance of this, stated with the estimate: 70%; the middle value is on the limit's open side.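

The step from compound 1 to compound 4 cannot be read, because both values are limits of the assay and not numbers: the limit of > 80% in this assay, at which 4 of the 4 values shown sit.

The compounds shown leave open how these four compare in this assay, and so whether (methylamino)methyl in place of ethylcarbamoyl changes the percent remaining at all.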